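Cytotoxicity of cyclopropylidene nucleoside analogues: from hexylsulfanyl to benzylsulfanyl

The source may report more compounds than this note shows. Statements on the series, on what has been measured and on what is new or still open speak of the compounds shown alone.

Compound 1 `Nc1nc(NCc2ccccc2)c2ncn(/C=C3/CC3(CO)CO)c2n1` gives > 20000 nM in an ADME assay on CCRF-HSB-2 cells (Homo sapiens) for cytotoxicity, with a stated time of 7 days (a higher number here means that more compound is tolerated, a lower number that less compound is tolerated), a limit of the assay rather than a number. Compound 2 `CCCCCCSc1nc(N)nc2c1ncn2/C=C1/CC1(CO)CO` gives 60000 nM in this assay. Compound 3 `Nc1nc2c(ncn2/C=C2/CC2(CO)CO)c(=O)[nH]1` gives > 20000 nM in this assay, again a limit and not a number.

Going by the values given here, compound 2 therefore holds the only number among the three; the other two values are limits. Among the compounds with values here, the one step between measured neighbours, a step that the limit leaves unreadable from compound 1 to compound 2, is a change of hexylsulfanyl in place of benzylamino on an aromatic carbon, and its size cannot be read because of the limit of > 20000 nM in this assay, at which 2 of the 3 values shown sit. Compound 4 `Nc1nc(SCc2ccccc2)c2ncn(/C=C3/CC3(CO)CO)c2n1` is not yet measured. It differs from compound 2 by phenyl in place of pentyl on a saturated chain carbon bound to a sulfur. Within the data shown here, no measured step carries a phenyl in place of pentyl, and the only step that touches this part of the molecule is unreadable, so no direction beyond the scatter can be drawn from the data. Compound 4 is accordingly expected to lie near compound 2, at an estimated 40000 nM with a range of 15000 nM to 120000 nM, a step of a 1.5-fold lower number from compound 2 to compound 4 (0.18 log units; within the scatter) that is expected to stay within the scatter.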

Compound 4, half-maximal cytotoxic concentration: > 100000 nM
Compound 4: only a limit was reported (the forecaster's own chance of this, stated with the estimate: 35%); at least 2.5-fold (0.39 log units) between middle value and limit.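

In this assay compound 4 gives > 100000 nM, a limit of the assay and not a number. Hexylsulfanyl to benzylsulfanyl yields the first readable step at this place, an at least 1.6-fold higher number from compound 2 to compound 4 (0.22 log units; that floor lies within the scatter), so phenyl in place of pentyl on a saturated chain carbon bound to a sulfur brings no lower number, although the floor of that step does not by itself clear the scatter. The change from benzylamino to benzylsulfanyl on an aromatic carbon stays unreadable because both of its ends are limits, the lower of them being this: the limit of > 20000 nM in this assay, at which 2 of the 4 values shown sit.

On these data alone, how far compound 4 truly lies from compound 2 remains open. As far as these compounds go, it is also open whether the aromatic ring matters here or any sulfur substituent of similar size would do, as a cyclohexylmethyl group or a longer chain such as octyl could show.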